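Losing the benzyl group from the shared core

The source may hold more compounds than are shown below. What is called first, only, known or untested is meant among the compounds shown, and "the series" means these compounds.

compound 1 `CCN(CC)Cc1ccc2nc(NC(=O)N/N=C/c3cn(Cc4ccc(C(C)(C)C)cc4)c4ccccc34)sc2c1` - 1710 nM
compound 2 `CCN(CC)Cc1ccc2nc(NC(=O)N/N=C/c3cn(Cc4ccc(Cl)cc4)c4ccccc34)sc2c1` - 2940 nM

For the measured compounds named here, compound 2 reads 2940 nM in a functional assay on A549 cells (Homo sapiens) for cytotoxicity, read by MTT assay, with a stated time of 72 h (on this read-out lower numbers stand for stronger inhibition and higher numbers for weaker inhibition), and lies within the scatter of compound 1 on the only two numbers available. Compound 3 `CCN(CC)Cc1ccc2nc(NC(=O)N/N=C/c3c[nH]c4ccccc34)sc2c1` carries hydrogen in place of 4-chlorobenzyl on an aromatic nitrogen. Going by the values given here, only one measured step bears on this change. That step, a 1.7-fold higher number from compound 1 to compound 2 (0.24 log units; within the scatter) and nothing more, puts chloro in place of tert-butyl on an aromatic carbon and keeps the benzyl group. Among the compounds with values here, no measured compound lacks that group, so its loss remains untested. A move to a higher number beyond the scatter is nevertheless expected in this assay with wide uncertainty. The estimated change is a 2.7-fold higher number from compound 2 to compound 3 (0.43 log units; beyond the scatter) on this reasoning. For compound 3 the estimate is 8000 nM with 2500 nM to 30000 nM as its expected range.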

Compound 3, half-maximal inhibitory concentration: 3300 nM
Compound 3: middle estimate off by 2.4-fold (0.38 log units), on the high side, within the range that was stated.
By their numbers in this assay, from the lowest: compounds 1, 2 and 3 (each within the scatter of the next).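

In this assay, taking the whole 4-chlorobenzyl group off the aromatic nitrogen gives a 1.1-fold higher number from compound 2 to compound 3 (0.05 log units; within the scatter) and taking off the 4-(tert-butyl)benzyl group gives a 1.9-fold higher number from compound 1 to compound 3 (0.29 log units; within the scatter). The earlier pair varied only the substituent on the benzyl ring, whereas these steps show that, among these three compounds, losing the six-membered aromatic ring and the rest of the group leaves the number within the scatter and that an unsubstituted aromatic nitrogen is compatible with this level of cytotoxicity. Nothing available explains this result.

On these data alone, whether a small methyl group on that nitrogen would read the same stays open. So does the effect of a chain ending in an amine or a carboxylic acid, and these compounds do not show whether any group at this position can move the number beyond the scatter.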